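Removing one methoxy group from a linked chalcone-coumarin

The source may report more compounds than this note shows. Statements on the series, on what has been measured and on what is new or still open speak of the compounds shown alone.

Three compounds share a long framework in which a coumarin is tied through a chain and a triazole to a chalcone-like diene ketone. Compound 1 `COc1cc(/C=C/C(=O)/C=C/c2ccccc2)ccc1OCc1cn(CCCCOc2cc(=O)oc3ccccc23)nn1`, compound 2 `COc1ccccc1/C=C/C(=O)/C=C/c1ccc(OCc2cn(CCCCOc3cc(=O)oc4ccccc34)nn2)c(OC)c1` and compound 3 `COc1ccc(/C=C/C(=O)/C=C/c2ccc(OCc3cn(CCCOc4cc(=O)oc5ccccc45)nn3)c(OC)c2)cc1OC` were tested in a functional assay on HCT-116 cells (Homo sapiens) for inhibition, read by sulforhodamine B assay, with a stated time of 48 h, tested at 50 uM; on this read-out higher numbers stand for more inhibition of growth at the one concentration tested and lower numbers for less inhibition of growth. In this assay compound 1 gives 34%, compound 2 gives 43% and compound 3 gives 67%. Compound 2 and compound 1 differ by hydrogen in place of methoxy on an aromatic carbon, and the step of a number 9 percentage points lower from compound 2 to compound 1 (within the scatter). How the core of compound 3 differs from that of compound 2 is not broken down here.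

Compound 4 `COc1ccc(/C=C/C(=O)/C=C/c2ccc(OCc3cn(CCCOc4cc(=O)oc5ccccc45)nn3)c(OC)c2)cc1` has not yet been measured. It differs from compound 3 by hydrogen in place of methoxy on an aromatic carbon. This is the same kind of change as from compound 2 to compound 1, but the surroundings differ: there the place was ortho to a large group, here it is ortho to a methoxy group and meta to a large group.

Given that compound 3 gives 67% and that the earlier step from compound 2 to compound 1 stayed within the scatter, the step from compound 3 to compound 4 is expected to be a number 11 percentage points lower from compound 3 to compound 4 (beyond the scatter). Compound 4 is therefore estimated at 56%, between 40% and 70%.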

Compound 4, percent growth inhibition at one concentration: 54%
The estimate for compound 4 lay 2 percentage points above the measured number; measured number inside the range.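

In this assay, replacing one methoxy group with hydrogen, which turns the 3,4-dimethoxyphenyl end into 4-methoxyphenyl, gives a number 13 percentage points lower from compound 3 to compound 4 (beyond the scatter). Only this step lies beyond the usual scatter, but its size cannot be told apart from that of the earlier step, so on these two cores the change carries over with a similar result: the same change on two cores in this assay, a number 9 percentage points lower (within the scatter) from compound 2 to compound 1 and a number 13 percentage points lower (beyond the scatter) from compound 3 to compound 4, 4 percentage points apart, within the scatter of two such steps

This does not show that the change would behave the same way on any other core, since two cores are a small sample, the change sits in a different place on each, and each number comes from one concentration only.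

The compounds shown leave open what a hydroxyl group or a chlorine atom would do in place of the methoxy group. They also leave open whether a longer chain between the coumarin and the triazole would alter the size of this step.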